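Fluoro for hydrogen on the benzyl group, across two cores

The source may hold more compounds than are shown below. What is called first, only, known or untested is meant among the compounds shown, and "the series" means these compounds.

Compound 1 `CCOC(=O)C(=O)CC(=O)/C=C/c1cn(Cc2ccccc2)c2ccccc12` and compound 2 `CCOC(=O)C(=O)CC(=O)/C=C/c1cn(Cc2ccc(F)cc2)c2ccccc12` share one core; compound 3 `O=C(/C=C/c1cc(C(=O)c2ccccc2)cn1Cc1ccccc1)CC(=O)C(=O)O` and compound 4 `O=C(/C=C/c1cc(C(=O)c2ccccc2)cn1Cc1ccc(F)cc1)CC(=O)C(=O)O` share another. The difference between the two cores is not broken down here.

In an assay on isolated protein for inhibition of DNA nucleotidylexotransferase (Homo sapiens), read by scintillation counting, with a stated time of 10 min (a lower number here means a stronger inhibitor, a higher number a weaker inhibitor), compound 1 gives > 40 uM, which is a limit of the assay and not a number. In this assay compound 2 likewise gives > 40 uM, again a limit. Going by the values given here, the change from compound 1 to compound 2 is fluoro in place of hydrogen on an aromatic carbon, and its step is a step that the two limits leave unreadable from compound 1 to compound 2, the only evidence on it being (the limit of > 40 uM in this assay, at which 2 of the 3 values shown sit).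

In this assay, among the compounds with values here, compound 3 gives 16 uM, the one number in the set. Within the data shown here, the change from compound 3 to compound 4 is fluoro in place of hydrogen on an aromatic carbon, the same change as the one from compound 1 to compound 2, with the same placement word for word.

Since the earlier step cannot be read in size, the expectation for compound 4 rests on compound 3 alone, and the step is estimated as no change at the digits printed from compound 3 to compound 4 (within the scatter), close to no change, because compound 3 gives 16 uM and a single fluoro on the benzyl group is a small change. Compound 4 is therefore expected to give about 16 uM in this assay. The estimate for compound 4 spans 5 uM to 50 uM.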

Compound 4, concentration for 50% inhibition: 9.5 uM
Beside the measured number, compound 4's estimate is 1.7-fold (0.23 log units) above it, and the stated range covers the measured number.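

In this assay, fluoro in place of hydrogen on the benzyl group of the core of compound 3 gives a 1.7-fold lower number from compound 3 to compound 4 (0.23 log units; within the scatter), so on this core the two compounds cannot be told apart and the change from benzyl to 4-fluorobenzyl shows no effect beyond repeat-measurement noise. On the core of compound 1 the same change cannot be read, both values there being limits of the assay and not numbers: the limit of > 40 uM in this assay, at which 2 of the 4 values shown sit. Going by these compounds alone, the series therefore holds one readable instance of this change, which shows that it is tolerated on one core but does not show that it carries over from one core to the other, since there is no second step of known size to set beside this one.

The compounds shown leave open whether a larger group on the benzyl ring, such as chloro, methoxy or trifluoromethyl, in the same place would give a step beyond the scatter on the core of compound 3. They also leave open how the core of compound 1 would read with the free carboxylic acid of compound 3 in place of its ethyl ester, a pairing that could bring its values into readable range and test the fluoro change there.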